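Replacing Nitro with Chloro on the Aryl Ring

The source may hold more compounds than are shown below. What is called first, only, known or untested is meant among the compounds shown, and "the series" means these compounds.

Compound 1: `CO/C(O)=C1\C(C)=NC(C)=C(C(=O)OCCCN2C(=O)c3ccccc3S2(=O)=O)C1c1ccccc1[N+](=O)[O-]` gives 1.5 nM
Compound 2: `CC1=NC(C)=C(C(=O)OCCCN2C(=O)c3ccccc3S2(=O)=O)C(c2ccccc2[N+](=O)[O-])/C1=C(\O)OC(C)C` gives 1.2 nM
Compound 3: `COCCO/C(O)=C1\C(C)=NC(C)=C(C(=O)OCCCN2C(=O)c3ccccc3S2(=O)=O)C1c1ccccc1[N+](=O)[O-]` gives 2.7 nM

These three compounds share one core and differ only in the alkyl group on one ester oxygen. All were tested in a functional assay (aorta) with Oryctolagus cuniculus as the target; a higher number here means a weaker inhibitor, a lower number a stronger inhibitor. Compound 1 stands second highest of the three numbers; its nearest neighbour is compound 2 and its furthest is compound 3. The step of a 1.3-fold lower number from compound 1 to compound 2 (0.10 log units; within the scatter) stays within the scatter, as does a 1.8-fold higher number from compound 1 to compound 3 (0.26 log units; within the scatter); only a 2.3-fold higher number from compound 2 to compound 3 (0.35 log units; beyond the scatter) edges beyond it, and even that is modest.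

Compound 4 is `CO/C(O)=C1\C(C)=NC(C)=C(C(=O)OCCCN2C(=O)c3ccccc3S2(=O)=O)C1c1ccccc1Cl`. Relative to compound 1 the change is chloro in place of nitro on an aromatic carbon. None of the three measured steps touches this position: each of them alters the ester alkyl group, and the aryl ring is the same in compounds 1, 2 and 3. Going by the values given here, there is therefore no measured step that bears on the nitro-to-chloro swap, and no direction can be read from the data. The expectation is a number close to that of compound 1, with a broad range in either direction. Compound 4 is estimated at 2 nM, between 0.5 nM and 8 nM, so that the expected step is a 1.3-fold higher number from compound 1 to compound 4 (0.12 log units; within the scatter) in this assay.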

Compound 4, half-maximal inhibitory concentration: 1.8 nM
Beside the measured number, compound 4's estimate is 1.1-fold (0.05 log units) above it, within the range that was stated.
By their numbers in this assay, from the lowest: compounds 2, 1, 4 and 3 (each within the scatter of the next, the first and the last beyond it).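

Until this point the aryl ring was the same in every compound, so nothing yet spoke to this position. With the ester alkyl group held constant, swapping 2-nitrophenyl for 2-chlorophenyl gives, in this assay, a 1.2-fold higher number from compound 1 to compound 4 (0.08 log units; within the scatter), so the two compounds cannot be told apart in this pair: nitro, with its three heavy atoms and two hydrogen-bond acceptors, can give way to a single chlorine atom with no hydrogen-bond acceptors without a difference larger than the usual scatter of repeated measurements. Nothing shown explains why the two groups give such similar numbers, so the result describes what happens at this position and not the reason for it.

From the compounds shown here alone, only nitro and chloro appear on this aromatic carbon, so it remains open whether a much different group, such as an amine or a carboxylic acid, would give a number in the same range. Chloro also appears here only with the methyl group on the ester oxygen, leaving open how it behaves alongside isopropyl or 2-methoxyethyl.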